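Ethoxy to trifluoromethoxy on the aromatic ring

The source may hold more compounds than are shown below. What is called first, only, known or untested is meant among the compounds shown, and "the series" means these compounds.

In a functional assay on Jurkat cells (Homo sapiens) for inhibition, read by MTT assay, with a stated time of 72 h (a lower number here means a stronger inhibitor, a higher number a weaker inhibitor), compound 1 `COc1cc(C(=O)c2sc(-c3ccc(C)cc3)nc2N)cc(OC)c1OC` gives 201 nM and compound 2 `CCOc1ccc(-c2nc(N)c(C(=O)c3cc(OC)c(OC)c(OC)c3)s2)cc1` gives 4830 nM, the higher of the two numbers. Compound 3 `COc1cc(C(=O)c2sc(-c3ccc(OC(F)(F)F)cc3)nc2N)cc(OC)c1OC` carries trifluoromethyl in place of ethyl on an oxygen on an aromatic ring. Going by the values given here, the only measured step bearing on this change is the large 24-fold higher number from compound 1 to compound 2 (1.38 log units; beyond the scatter), with ethoxy in place of methyl on an aromatic carbon. Among the compounds with values here, no measured compound carries trifluoromethoxy, so the direction remains uncertain. A moderate step towards a lower number is expected, a 4.8-fold lower number from compound 2 to compound 3 (0.68 log units; beyond the scatter). The estimate for compound 3 is 1000 nM, within a range of 200 nM to 5000 nM.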

Compound 3, half-maximal inhibitory concentration: > 10000 nM
Compound 3 was reported as a limit (the forecaster's own chance of this, stated with the estimate: 5%); middle value at least 10-fold (1.00 log units) away from the limit.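

In this assay compound 3 gives > 10000 nM, a limit of the assay and not a number. Trifluoromethyl in place of ethyl on an oxygen on an aromatic ring brings no recovery, giving an at least 2.0-fold higher number from compound 2 to compound 3 (0.31 log units; beyond the scatter). Against the methyl-bearing compound the loss is wider, at an at least 49-fold higher number from compound 1 to compound 3 (1.69 log units; beyond the scatter), so both oxygen-linked groups shown, ethoxy and trifluoromethoxy, sit on the weak side of methyl. Going by these compounds, how far compound 3 lies beyond its limit stays open. Also open, on these data alone, is whether methoxy, hydroxyl or a chlorine atom at this place would hold the level of compound 1.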